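This account rests on a few compounds, and the source may have more. Where it says the series, first, only, none or still open, it means among the compounds named here.

Working notes on the series. The three measured compounds share one core and differ only in the group on the amide-type nitrogen: compound 1 `Cc1cc(NC(=O)Nc2ncccc2C)c2ccccc2n1` carries 3-methylpyridin-2-yl there, compound 2 `Cc1cc(NC(=O)Nc2cccc(Cl)c2)c2ccccc2n1` carries 3-chlorophenyl, compound 3 `Cc1cc(NC(=O)Nc2ccc(F)cc2)c2ccccc2n1` carries 4-fluorophenyl. In an ADME assay on HepG2 cells (Homo sapiens) for cytotoxicity, with a stated time of 72 h (a higher number here means that more compound is needed for the effect, a lower number that less compound is needed), compound 2 gives 19000 nM. In this assay compound 1 reaches only the assay limit, > 25000 nM. Compound 3 likewise reaches only the limit in this assay, > 25000 nM, so compound 3 stands without a number of its own. The steps across this position stay small: an at least 1.3-fold lower number from compound 1 to compound 2 (0.11 log units; that floor lies within the scatter) and an at least 1.3-fold higher number from compound 2 to compound 3 (0.11 log units; that floor lies within the scatter), while a step that the two limits leave unreadable from compound 1 to compound 3. Compound 4 `COC(=O)c1ccc(NC(=O)Nc2cc(C)nc3ccccc23)cc1` differs from compound 3 as follows: methoxycarbonyl in place of fluoro on an aromatic carbon. Among the compounds with values here, the steps that bear on this are the exchanges on the same nitrogen, none of which moves beyond the scatter, and because the limit of > 25000 nM in this assay, at which 2 of the 3 values shown sit, little movement is readable at all. No step beyond the scatter is expected in this assay, a number no higher from compound 3 to compound 4 (the limit leaves the size open). Compound 4 is therefore estimated at 25000 nM, between 12000 nM and 60000 nM, most likely reported again only as a limit.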

Compound 4, half-maximal effective concentration: 20000 nM
For compound 4 the middle estimate is 1.3-fold (0.10 log units) above the measured one; the measured number falls inside the stated range.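

In this assay the replacement of fluoro by the larger methoxycarbonyl, which brings hydrogen-bond acceptors to the aromatic carbon para to a large group, gives a measured number: compound 4 gives 20000 nM. The change is an at least 1.2-fold lower number from compound 3 to compound 4 (0.09 log units; that floor lies within the scatter), so even this larger group on the same ring produces no readable step beyond the scatter. The true size of the step is bounded on one side only, because compound 3 sits at the limit: the limit of > 25000 nM in this assay, at which 2 of the 4 values shown sit.

The compounds shown leave open whether a carboxylic acid or an amine on this aromatic carbon would produce a step beyond the scatter. They also leave open whether a longer chain in place of methoxycarbonyl would bring the number further from the limit.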